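From compound 3 to compound 4: one ring group exchanged

The compounds below may be only part of what the source reports. "The series", "measured", "known", "first", "only" and "open" are said of these compounds alone.

In a functional assay on MDA-MB-231 cells (Homo sapiens) for antiproliferative activity, read by MTT assay, with a stated time of 48 h (a higher number here means a weaker inhibitor, a lower number a stronger inhibitor), compound 1 `C=CS(=O)(=O)N1CCN(c2ncnc3sc(-c4ccccc4)cc23)CC1` gives 54200 nM as its reading, and compound 2 `C=CS(=O)(=O)N1CCN(c2ncnc3sc(-c4ccnc(Cl)c4)cc23)CC1` gives 27700 nM as its reading. Compound 3 `CN1CCN(c2ccc(-c3cc4c(N5CCN(C(=O)Nc6ccc(OC(F)(F)F)cc6)CC5)ncnc4s3)cc2)CC1` stands lowest of the three at 4600 nM and is the strongest inhibitor measured so far.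

Compound 4 `CN1CCN(c2ccc(-c3cc4c(N5CCN(C(=O)Nc6cc(C(F)(F)F)ccc6F)CC5)ncnc4s3)cc2)CC1` has not been measured. It carries 2-fluoro-5-(trifluoromethyl)phenyl in place of 4-(trifluoromethoxy)phenyl on an amide-type nitrogen, and the count runs as follows: 2-fluoro-5-(trifluoromethyl)phenyl in place of 4-(trifluoromethoxy)phenyl on an amide-type nitrogen.

Within the data shown here, no measured step covers this exchange. Among the measured compounds shown here, the one step available, a 2.0-fold lower number from compound 1 to compound 2 (0.29 log units; within the scatter), lies within the scatter and concerns a different exchange on an aromatic carbon, with 2-chloropyridin-4-yl in place of phenyl. It offers no reason to expect a large move in either direction. In this assay the expected step is a 1.1-fold lower number from compound 3 to compound 4 (0.04 log units; within the scatter) and that is no move beyond the scatter.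

For compound 4 the estimated value is 4200 nM with an expected range from 1800 nM to 10000 nM in this measurement.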

Compound 4, half-maximal inhibitory concentration: 9090 nM
The estimate for compound 4 lay 2.2-fold (0.34 log units) below the measured number, within the range that was stated.
By their numbers in this assay, from the lowest: compounds 3 and 4 (each within the scatter of the next); then compounds 2 and 1 (each within the scatter of the next).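

Among these compounds, this is the first measured exchange of the ring group on an amide-type nitrogen, and in this assay the result is a 2.0-fold higher number from compound 3 to compound 4 (0.30 log units; within the scatter), so the two compounds cannot be told apart here. The entering 2-fluoro-5-(trifluoromethyl)phenyl group has no oxygen and no hydrogen-bond acceptor, yet the reading does not move beyond the scatter, so this pair gives no sign that the oxygen of the leaving group is needed in this assay. Nothing measured here bears on what lies behind this result.

Still open, from the compounds shown here alone, is whether this nitrogen would hold its reading with an unsubstituted phenyl ring, a pyridine ring or a cyclohexyl ring. A phenyl ring carrying only the fluorine or only the trifluoromethyl group would be needed to separate the two parts of this exchange.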